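Swapping the fluorine position on the aryl amide of compound 3

The source may hold more compounds than are shown below. What is called first, only, known or untested is meant among the compounds shown, and "the series" means these compounds.

Compound 1 `CC(C)OC(=O)C1CN(C(=O)C2CCCCC2)CC(C)(C)c2cc(C#N)[nH]c21` gives 127% in an assay on HEK293 cells for agonist activity at Bile acid receptor (Homo sapiens), read by a luciferase reporter; a lower number here means a smaller maximal response, a higher number a larger maximal response. Compound 2 `CC(C)OC(=O)C1CN(C(=O)c2ccc(C#N)cc2)CC(C)(C)c2cc(C#N)[nH]c21` gives 91%. Compound 3 `CC(C)OC(=O)C1CN(C(=O)c2cccc(F)c2)CC(C)(C)c2cc(C#N)[nH]c21` gives 84%.

Compound 3 sits at the bottom of the three measured numbers in this assay. Its distance from compound 1 is clear, a number 43 percentage points lower from compound 1 to compound 3 (beyond the scatter), but its distance from compound 2 is not, a number 7 percentage points lower from compound 2 to compound 3 (within the scatter), so compounds 2 and 3 cannot be separated by these data.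

Compound 4 `CC(C)OC(=O)C1CN(C(=O)c2ccc(F)cc2)CC(C)(C)c2cc(C#N)[nH]c21` has not yet been measured. It differs from compound 3 only in the aryl group on the carbonyl carbon: 4-fluorophenyl in place of 3-fluorophenyl on a carbonyl carbon.

Of the measured steps, the one that bears most directly on this change is the swap of one aryl group for another on the same carbonyl carbon, a number 7 percentage points lower from compound 2 to compound 3 (within the scatter), which stayed within the scatter. The two large steps, a number 36 percentage points lower from compound 1 to compound 2 (beyond the scatter) and a number 43 percentage points lower from compound 1 to compound 3 (beyond the scatter), both trade a cyclohexyl for an aryl ring and say less about moving a fluorine within an aryl ring. Compound 4 is therefore expected to land close to compound 3, with a step of a number 3 percentage points higher from compound 3 to compound 4 (within the scatter) that stays within the scatter. The estimate for compound 4 is 87%, with a range of 70% to 105%.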

Compound 4, largest response reached (reported as efficacy), in percent of the reference or control that the assay uses in the Bile acid receptor assay: 85%
Beside the measured number, compound 4's estimate is 2 percentage points above it; measured number inside the range.
By their numbers in the Bile acid receptor assay, from the lowest: compounds 3, 4 and 2 (each within the scatter of the next); then compound 1.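

In the Bile acid receptor assay, the move of the fluorine around the ring makes no readable difference, a number 1 percentage points higher from compound 3 to compound 4 (within the scatter), and the change of the para-free wording of the earlier pair now extends to a third aryl group: fluoro in place of cyano gives a number 6 percentage points lower from compound 2 to compound 4 (within the scatter), also within the scatter, while a number 42 percentage points lower from compound 1 to compound 4 (beyond the scatter) shows that 4-fluorophenyl stands apart from cyclohexyl just as the other two aryl groups do. In a physicochemical assay for solubility, at pH 7.4 (a lower number here means a less soluble compound, a higher number a more soluble compound), compound 3 gives > 100 ug/mL, which is a limit of the assay and not a number. In the physicochemical assay, compound 4 gives > 100 ug/mL, again a limit, so the step between the two cannot be read: the limit of > 100 ug/mL in the physicochemical assay, at which 2 of the 2 values shown sit.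

The compounds shown leave open whether an amine or a carboxylic acid in place of the fluorine would also stay within the scatter of these aryl amides. They also leave open whether a longer chain on the carbonyl carbon, in place of the aryl group, would reach the response of compound 1.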